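The compounds below may be only part of what the source reports. "The series", "measured", "known", "first", "only" and "open" are said of these compounds alone.

Compound 1 `C/N=C(\S)OC[C@H]1OC(n2cnc3c(NC4CCOC4)ncnc32)[C@H](O)[C@@H]1O` sets the strongest mark among the three measured compounds: in an assay on DDT1 cells (Cricetulus griseus) for binding affinity to adenosine receptor A1 (Homo sapiens), read by radioligand binding (a lower number here means a stronger inhibitor, a higher number a weaker inhibitor), compound 1 gives 45 nM. Compound 2 `CCCCNC(=O)OC[C@H]1OC(n2cnc3c(NC4CCOC4)ncnc32)[C@H](O)[C@@H]1O` gives 1410 nM in this assay, and the step of a 31-fold higher number from compound 1 to compound 2 (1.50 log units; beyond the scatter) is the largest of the set. Compound 3 `CCCC/N=C(\S)OC[C@H]1OC(n2cnc3c(NC4CCOC4)ncnc32)[C@H](O)[C@@H]1O` gives 157 nM in this assay; it stands second highest of the three numbers, with a 3.5-fold higher number from compound 1 to compound 3 (0.54 log units; beyond the scatter) on one side and a 9.0-fold lower number from compound 2 to compound 3 (0.95 log units; beyond the scatter) on the other, so it sits nearer to compound 1 than to compound 2.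

Compound 4 `CC(C)/N=C(\S)OC[C@H]1OC(n2cnc3c(NC4CCOC4)ncnc32)[C@H](O)[C@@H]1O` differs from compound 3 by isopropyl in place of butyl on a double-bonded nitrogen. Among the compounds with values here, the one measured step that touches this chain is a 3.5-fold higher number from compound 1 to compound 3 (0.54 log units; beyond the scatter), in which propyl in place of hydrogen raised the number modestly; the change from compound 3 to compound 4 goes the other way in size, since isopropyl is the smaller group as counted, though it does not return to the group of compound 1. Within the data shown here, no measured pair shows a branched chain on this nitrogen. The expectation is therefore a modest lowering of the number in this assay for compound 4, of the order of a 1.7-fold lower number from compound 3 to compound 4 (0.24 log units; within the scatter), with a fair chance that it stays within the scatter of compound 3. Compound 4 is estimated at 90 nM, expected to fall between 35 nM and 250 nM.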

Compound 4, inhibition constant: 36 nM
The estimate for compound 4 lay 2.5-fold (0.40 log units) above the measured number; the range from low to high includes it.
By their numbers in this assay, from the lowest: compounds 4 and 1 (each within the scatter of the next); then compound 3; then compound 2.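

At the double-bonded nitrogen, chain size alone does not set the number in this assay: isopropyl in place of butyl gives a 4.4-fold lower number from compound 3 to compound 4 (0.64 log units; beyond the scatter) and so moves beyond the scatter, while isopropyl in place of methyl gives a 1.3-fold lower number from compound 1 to compound 4 (0.10 log units; within the scatter) and stays within it, so methyl and isopropyl cannot be told apart here while butyl stands apart from both. The step of a 39-fold lower number from compound 2 to compound 4 (1.59 log units; beyond the scatter) is the widest span in the set, but it changes the chain and puts sulfur in place of oxygen within one group, so it cannot show how much each change contributes. Nothing given here explains why these changes have these effects.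

The compounds shown leave open whether the branch itself matters or only the chain length, which a straight propyl chain, an ethyl group or a tert-butyl group on this nitrogen would help to settle. They also leave open how isopropyl behaves in the group that holds oxygen in place of sulfur, a compound that would separate the two changes within the step from the butyl compound with oxygen.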